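A few compounds are considered here, and "the series" means these few. Any claim that something is new, unique, unknown or untested is made for them only; others in the source may bear on it.

Measured compounds:
compound 1 `CN(C(=O)c1c(O)c2cc(Sc3ccccc3)ccc2n(C)c1=O)c1ccccc1`: 100%
compound 2 `CN(C(=O)c1c(O)c2cc(Oc3ccccc3)ccc2n(C)c1=O)c1ccccc1`: 26%
compound 3 `CSc1ccc2c(c1)c(Cl)c(C(=O)N(C)c1ccccc1)c(=O)n2C`: -1%

Within the data shown here, in a functional assay on the whole organism for inhibition, with Mus musculus as the target, at a dose of 32 mg/kg by the oral route (on this read-out higher numbers stand for more inhibition at the one dose given (going by the name of the read-out) and lower numbers for less inhibition), compound 1 gives 100% and compound 2 gives 26%; the one measured step, a number 74 percentage points lower from compound 1 to compound 2 (beyond the scatter), is large. Compound 3 gives -1% in this assay, the lowest of the three numbers, beyond the scatter from both compound 2 and compound 1.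

Compound 4 `COc1c(C(=O)N(C)c2ccccc2)c(=O)n(C)c2ccc(SC)cc12` follows from compound 3 by one change: methoxy in place of chloro on an aromatic carbon. Among the measured compounds shown here, no measured step bears on this change. For the measured compounds named here, the only step known, a number 74 percentage points lower from compound 1 to compound 2 (beyond the scatter), concerns an exchange of phenoxy for phenylsulfanyl elsewhere on the core, and compounds 1 and 2 differ from compound 3 in more than one place, so nothing connects them to compound 3 by a single step. The expected step of a number 11 percentage points higher from compound 3 to compound 4 (beyond the scatter) is therefore an estimate that leans only slightly upward from compound 3, within or near the usual scatter. Compound 4 is accordingly expected to give about 10% in this assay, with a range from -10% to 45%.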

Compound 4, a percentage reported as inhibition, in the whole organism at one dose (the size of the read-out at that dose, not a potency): 94%
The estimate for compound 4 lay 84 percentage points below the measured number; measured number above the stated range.
By their numbers in this assay, from the lowest: compound 3; then compound 2; then compounds 4 and 1 (each within the scatter of the next).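

In this assay, methoxy in place of chloro on the aromatic carbon opposite the ring nitrogen gives a number 95 percentage points higher from compound 3 to compound 4 (beyond the scatter), a large step from a single change. Among these compounds, the only earlier step, a number 74 percentage points lower from compound 1 to compound 2 (beyond the scatter), concerned another place on the core, so this is the first direct sign that the group on this carbon can by itself shift the read-out so strongly. Nothing available accounts for the size of this step.

The compounds shown leave open whether an amino group, an ethoxy group or a fluoro group on this carbon would give a number closer to that of compound 3 or to that of compound 4. They also leave open whether the exchange of chloro for methoxy would give a step of similar size with phenylsulfanyl or phenoxy elsewhere on the core.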